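Swapping the aryl group on the piperidine nitrogen

The compounds below may be only part of what the source reports. "The series", "measured", "known", "first", "only" and "open" are said of these compounds alone.

Measured so far in a functional assay for antagonist activity at transient receptor potential cation channel subfamily V member 1 (Homo sapiens), read by FLIPR and calcium flux; a higher number here means a weaker inhibitor, a lower number a stronger inhibitor:
compound 1, `Cc1cccc(N2CCC(C(=O)Nc3ccc4c(c3)NC(=O)CO4)CC2)c1`, gives 490 nM;
compound 2, `O=C1COc2ccc(NC(=O)C3CCN(c4ccccc4Br)CC3)cc2N1`, gives 160 nM;
compound 3, `Cc1ccccc1N1CCC(C(=O)Nc2ccc3c(c2)NC(=O)CO3)CC1`, gives 150 nM.

Compound 3 gives the lowest number of the three, yet compound 2 sits within the scatter of it, so the two cannot be ranked. The next compound, compound 4 with the structure `O=C1COc2ccc(NC(=O)C3CCN(c4cccc(Cl)c4)CC3)cc2N1`, differs from compound 3 in one place: 3-chlorophenyl in place of 2-methylphenyl on an amine nitrogen in a ring. For the measured compounds named here, two measured steps bear on this. The step of a 3.3-fold lower number from compound 1 to compound 3 (0.51 log units; beyond the scatter) shows that moving a methyl from the 3-position to the 2-position lowers the number; the step of a 1.1-fold lower number from compound 2 to compound 3 (0.03 log units; within the scatter) shows that methyl and bromo at the 2-position give the same number. Undoing the positional move while swapping the group is therefore expected to raise the number, roughly back toward compound 1, as the step of a 2.7-fold higher number from compound 3 to compound 4 (0.43 log units; beyond the scatter). Compound 4 is estimated at 400 nM in this assay, within a range from 150 nM to 1100 nM.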

Compound 4, half-maximal inhibitory concentration: 190 nM
Estimate against measurement, compound 4: 2.1-fold (0.32 log units) above; low and high end bracket the measured number.
By their numbers in this assay, from the lowest: compounds 3, 2 and 4 (each within the scatter of the next); then compound 1.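

In this assay, the 3-position is not poor in itself: the step of a 2.6-fold lower number from compound 1 to compound 4 (0.41 log units; beyond the scatter) shows that chloro in place of methyl there matters, so the earlier gain from moving to the 2-position holds only for methyl. The 3-chlorophenyl group cannot be told apart from the 2-substituted groups, given a 1.3-fold higher number from compound 3 to compound 4 (0.10 log units; within the scatter) and a 1.2-fold higher number from compound 2 to compound 4 (0.07 log units; within the scatter) on the same ring nitrogen. Nothing at hand explains why these numbers fall as they do.

Still open, from the compounds shown here alone, is how 2-chlorophenyl would compare with 3-chlorophenyl, which would show whether position matters for chloro at all. Also open, going by these compounds, is how a methoxy or nitrile group on the same phenyl ring would read.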